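The source may report more compounds than this note shows. Statements on the series, on what has been measured and on what is new or still open speak of the compounds shown alone.

Measured compounds in the series:

compound 1 `O=C(N/N=C/c1ccccc1[N+](=O)[O-])Nc1ccc(Br)cc1` — 300 mg/kg
compound 2 `COc1ccc(/C=N/NC(=O)Nc2ccc(Br)cc2)cc1OC` — 300 mg/kg
compound 3 `C/C(=N\NC(=O)Nc1ccc(Br)cc1)c1ccccc1` — 100 mg/kg

In a functional assay on the whole organism with Mus musculus as the target, in the maximal electroshock model, with a stated time of 0.5 h (a higher number here means that more compound is needed for the effect, a lower number that less compound is needed), compound 1 gives 300 mg/kg and compound 2 gives 300 mg/kg. Compound 3, which carries a methyl on the imine carbon and an unsubstituted phenyl, gives 100 mg/kg, the lowest of the three numbers; its gap to compound 1 and its gap to compound 2 are the same size and both lie beyond the scatter. No two of the measured compounds differ in only one place, so no single step can be read from them.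

Compound 4 `C/C(=N\NC(=O)Nc1ccc(Br)cc1)c1ccc(N)cc1` is not yet measured. Relative to compound 3 the change is amino in place of hydrogen on an aromatic carbon. Within the data shown here, none of the measured pairs isolates this change: compound 1 and compound 2 carry substituents on this ring but differ from compound 3 elsewhere as well, so their numbers give no direction for it. With nothing to anchor it, the step is expected to stay within the scatter, with no preferred direction.

Compound 4 is expected to give 100 mg/kg, with a range from 30 mg/kg to 300 mg/kg. The implied step, no change at the digits printed from compound 3 to compound 4 (within the scatter), is estimated to fall within the usual scatter.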

Compound 4, minimum effective dose: 300 mg/kg
Estimate against measurement, compound 4: 3.0-fold (0.48 log units) below; measured number inside the range.
By their numbers in this assay, from the lowest: compound 3; then compounds 1, 2 and 4 (each within the scatter of the next).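

In this assay, among these compounds, the change from phenyl to 4-aminophenyl gives a 3.0-fold higher number from compound 3 to compound 4 (0.48 log units; beyond the scatter), the first step that can be read from a single change. The aromatic carbon para to a large group is therefore not indifferent to substitution: with amino in place of hydrogen, more compound is needed for the effect, and here the unsubstituted phenyl of compound 3 is the better of the two. This is one step at one position, so it sets no trend for substituents in general, and no measurement in hand bears on what lies behind it.

From the compounds shown here alone, it remains open whether this step belongs to amino specifically or would follow any replacement of hydrogen at this carbon; a hydroxyl, a dimethylamino group or a carboxylic acid at the same place would help separate those readings. The methyl on the imine carbon also remains unresolved, as no pair shown isolates it, and an ethyl group at that carbon would extend the series there.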